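Replacing the benzoyl of compound 2 with a nitrile

The source may report more compounds than this note shows. Statements on the series, on what has been measured and on what is new or still open speak of the compounds shown alone.

Measured so far:
Compound 1, `CC(=O)/C(=C\c1c(-c2ccccc2)[nH]c2ccccc12)S(=O)(=O)c1ccccc1`: 2200 nM
Compound 2, `O=C(/C(=C\c1c(-c2ccccc2)[nH]c2ccccc12)S(=O)(=O)c1ccccc1)c1ccccc1`: 7600 nM

Of the compounds shown here, two have been tested in a functional assay on RPMI-8226 cells (Homo sapiens) for inhibition, read by sulforhodamine B assay, with a stated time of 48 h; a lower number here means a stronger inhibitor of growth, a higher number a weaker inhibitor of growth. Compound 1 gives 2200 nM, while compound 2 gives 7600 nM, the higher of the two numbers: the step of a 3.5-fold higher number from compound 1 to compound 2 (0.54 log units; beyond the scatter) goes beyond the scatter, so the larger group on the carbonyl carbon weakens growth inhibition in this assay.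

Compound 3, `N#C/C(=C\c1c(-c2ccccc2)[nH]c2ccccc12)S(=O)(=O)c1ccccc1`, has not yet been measured. It differs from compound 2 in one place: cyano in place of benzoyl on a double-bonded chain carbon bound to a double-bonded chain carbon and a sulfonyl sulfur. Within the data shown here, only the step from compound 1 to compound 2 bears on this change, and it shows that the smaller substituent at this position gave the lower number. Cyano is the smallest of the three groups, so compound 3 is expected to return at least to the level of compound 1, estimated as a 3.8-fold lower number from compound 2 to compound 3 (0.58 log units; beyond the scatter). The value for compound 3 is therefore estimated at 2000 nM, with a range from 600 nM to 7000 nM.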

Compound 3, concentration for 50% growth inhibition: 714 nM
For compound 3 the middle estimate is 2.8-fold (0.45 log units) above the measured one; the range from low to high includes it.
By their numbers in this assay, from the lowest: compound 3; then compound 1; then compound 2.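

In this assay cyano in place of benzoyl gives an 11-fold lower number from compound 2 to compound 3 (1.03 log units; beyond the scatter) and cyano in place of acetyl gives a 3.1-fold lower number from compound 1 to compound 3 (0.49 log units; beyond the scatter) at the same place, so the nitrile does more than make up the ground lost with benzoyl: it goes past the acetyl compound as well. A carbonyl at this place is not needed for growth inhibition, as compound 3 has none and still gives the lowest number of the three. Across these three compounds the number falls as the group gets smaller, and none goes against that order, though three groups make only a short series.

Going by these compounds, whether the order continues with a methyl group or a lone hydrogen, and where a primary amide or a methyl ester would fall, stays open. Nothing available explains why the nitrile gives the lowest number.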